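Thiophene Replaces Methoxyphenyl on the Imidazole Core

A few compounds are considered here, and "the series" means these few. Any claim that something is new, unique, unknown or untested is made for them only; others in the source may bear on it.

Measured compounds:
Compound 1 `O=C(O)C[C@H](O)C[C@H](O)CCn1c(C(F)(F)F)nc(-c2ccc(F)cc2)c1-c1ccc(F)cc1` gives 38 nM in an assay on microsomes from liver for inhibition of 3-hydroxy-3-methylglutaryl-coenzyme A reductase (Rattus norvegicus); a higher number here means a weaker inhibitor, a lower number a stronger inhibitor.
Compound 2 `O=C(O)C[C@H](O)C[C@H](O)CCn1c(C(F)(F)F)nc(-c2ccc(F)cc2)c1-c1cccc(Cl)c1` gives 41 nM in this assay.
Compound 3 `COc1cccc(-c2c(-c3ccc(F)cc3)nc(C(F)(F)F)n2CC[C@@H](O)C[C@@H](O)CC(=O)O)c1` gives 135 nM in this assay.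

Compound 3 stands highest of the three: compared with it, compound 2 reads a 3.3-fold higher number from compound 2 to compound 3 (0.52 log units; beyond the scatter) and compound 1 reads a 3.6-fold higher number from compound 1 to compound 3 (0.55 log units; beyond the scatter). Compound 4 `O=C(O)C[C@H](O)C[C@H](O)CCn1c(C(F)(F)F)nc(-c2ccc(F)cc2)c1-c1cccs1` differs from compound 3 by thiophen-2-yl in place of 3-methoxyphenyl on an aromatic carbon. For the measured compounds named here, the steps that bear on this change all exchange the same aryl ring: a 1.1-fold higher number from compound 1 to compound 2 (0.03 log units; within the scatter) and a 3.6-fold higher number from compound 1 to compound 3 (0.55 log units; beyond the scatter). Since the methoxy in compound 3 seems to account for its higher number, the thiophen-2-yl is expected to give a modest downward step, a 2.7-fold lower number from compound 3 to compound 4 (0.43 log units; beyond the scatter). Compound 4 is therefore estimated at 50 nM, between 20 nM and 150 nM.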

Compound 4, half-maximal inhibitory concentration: 215 nM
Estimate against measurement, compound 4: 4.3-fold (0.63 log units) below; measured number above the stated range.
By their numbers in this assay, from the lowest: compounds 1 and 2 (each within the scatter of the next); then compounds 3 and 4 (each within the scatter of the next).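

Thiophen-2-yl in place of 3-methoxyphenyl gives a 1.6-fold higher number from compound 3 to compound 4 (0.20 log units; within the scatter) so a ring without the methoxy does not by itself return the number to the level of compound 1 or compound 2. Thiophen-2-yl in place of the halogen-bearing rings gives a 5.2-fold higher number from compound 2 to compound 4 (0.72 log units; beyond the scatter) and a 5.7-fold higher number from compound 1 to compound 4 (0.75 log units; beyond the scatter) so this position separates the two halogen-bearing aryl groups from both other rings shown. No measurement shown explains these differences.

The compounds shown leave open how a plain phenyl ring or a chlorine-bearing thiophene would read at this position in this assay and so whether the ring itself or its substituent sets the number.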